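The compounds below may be only part of what the source reports. "The series", "measured", "known", "first", "only" and "open" are said of these compounds alone.

Working notes on a small series assessed in an assay on HEK293 cells for inhibition of sodium-dependent dopamine transporter (Homo sapiens), read by scintillation counting, with stated times of 5 min and 1 min; on this read-out lower numbers stand for stronger inhibition and higher numbers for weaker inhibition. Two compounds carry numbers. Compound 1, `[O-][S+](Cc1nc(O)cc(C(F)(F)F)n1)C(c1ccccc1)c1ccccc1`, gives 40400 nM. Compound 2, `CC(C)c1nnsc1C[S+]([O-])C(c1ccccc1)c1ccccc1`, gives 69100 nM. Where compound 2 stands: the gap between its number and that of compound 1 lies within the usual scatter of this kind of measurement, so the two cannot be separated and neither is placed ahead of the other.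

Compound 3, `[O-][S+](Cc1ccncc1)C(c1ccccc1)c1ccccc1`, has not yet been measured. It differs from compound 2 by pyridin-4-yl in place of 4-isopropyl-1,2,3-thiadiazol-5-yl on a saturated chain carbon bound to a sulfur. Among the measured compounds shown here, no step between measured compounds that differ in one place is available, so nothing measured speaks directly to this change. The change swaps one aromatic group for another on the saturated chain carbon bound to a sulfur, with the rest of the molecule untouched. For the measured compounds named here, since the two known numbers sit together within the scatter despite carrying different groups at that carbon, the step from compound 2 to compound 3 is expected to be small. The expected step is a 1.3-fold lower number from compound 2 to compound 3 (0.10 log units; within the scatter), none beyond the scatter. Compound 3 is therefore estimated at 55000 nM, within a range from 15000 nM to 200000 nM.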

Compound 3, half-maximal inhibitory concentration: 63500 nM
Estimate against measurement, compound 3: 1.2-fold (0.06 log units) below; the measured number falls inside the stated range.
By their numbers in this assay, from the lowest: compounds 1, 3 and 2 (each within the scatter of the next).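

In this assay, the series now has its first comparison that differs in one place: pyridin-4-yl in place of 4-isopropyl-1,2,3-thiadiazol-5-yl on a saturated chain carbon bound to a sulfur gives a 1.1-fold lower number from compound 2 to compound 3 (0.04 log units; within the scatter). On this read-out, a six-membered aromatic ring with 1 hetero atom therefore cannot be separated from a five-membered aromatic ring with 3 hetero atoms carrying an isopropyl group at this place. Nothing available offers an explanation for the size of this step.

Every group shown at this place contains an aromatic ring with at least one hetero atom, so it remains open whether an amine, a carboxylic acid, a plain phenyl ring or a longer chain there would move the number beyond the scatter. The rest of the molecule is the same in compound 2 and compound 3, and this pair says nothing about how the number responds to a change elsewhere, such as replacing one of the phenyl rings with a cyclohexyl ring.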